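Ring closure of the alkoxy side chain on the shared core

The source may report more compounds than this note shows. Statements on the series, on what has been measured and on what is new or still open speak of the compounds shown alone.

For the measured compounds named here, compound 3 `CCc1sc(CCc2cc(OC(CC)CC)cc(NCc3cc(Cl)cc(NC(=O)OC(C)C)c3)n2)nc1C` gives 5.5 nM in an assay on cells for binding affinity to Neuropeptide Y receptor type 1 (Homo sapiens) (a lower number here means a stronger inhibitor, a higher number a weaker inhibitor), the lowest of the three numbers so far. Compound 2 `CCc1sc(CCc2cc(OCC3(C)CC3)cc(NCc3cc(Cl)cc(NC(=O)OC(C)C)c3)n2)nc1C` gives 17 nM and compound 1 `CCCCCCCOc1cc(CCc2nc(C)c(CC)s2)nc(NCc2cc(Cl)cc(NC(=O)OC(C)C)c2)c1` gives 72 nM. Compound 4 `CCc1sc(CCc2cc(OC3CCCC3)cc(NCc3cc(Cl)cc(NC(=O)OC(C)C)c3)n2)nc1C` carries cyclopentyl in place of pentan-3-yl on an oxygen on an aromatic ring. Going by the values given here, the steps that bear on this change are a 13-fold lower number from compound 1 to compound 3 (1.12 log units; beyond the scatter) and a 3.1-fold lower number from compound 2 to compound 3 (0.49 log units; beyond the scatter), with a 4.2-fold lower number from compound 1 to compound 2 (0.63 log units; beyond the scatter) in between; both branched groups on the oxygen gave lower numbers than the straight chain. Cyclopentyl matches pentan-3-yl in size and branching, so only a small step in this assay, if any beyond the scatter, is expected: a 1.3-fold higher number from compound 3 to compound 4 (0.10 log units; within the scatter). For compound 4 the estimate is 7 nM, between 3 nM and 18 nM.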

Compound 4, half-maximal inhibitory concentration: 11 nM
Compound 4: the middle estimate sits 1.6-fold (0.20 log units) below what was measured, and the stated range covers the measured number.
By their numbers in this assay, from the lowest: compounds 3, 4 and 2 (each within the scatter of the next, the first and the last beyond it); then compound 1.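

In this assay, closing pentan-3-yl into cyclopentyl on the oxygen gives a 2.0-fold higher number from compound 3 to compound 4 (0.30 log units; within the scatter), so the open and ring forms cannot be told apart at this position. The same holds against (1-methylcyclopropyl)methyl, with a 1.5-fold lower number from compound 2 to compound 4 (0.19 log units; within the scatter). Cyclopentyl still gives a 6.5-fold lower number from compound 1 to compound 4 (0.82 log units; beyond the scatter), so all three non-linear groups shown give lower numbers than heptyl, with no compound shown against this. On these data alone, whether cyclobutyl, cyclohexyl or tetrahydropyranyl on this oxygen would keep the number in this range remains open. No supporting measurement accounts for the differences among these groups.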